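Working notes: fluoro in place of chloro

The source may report more compounds than this note shows. Statements on the series, on what has been measured and on what is new or still open speak of the compounds shown alone.

- compound 1 `Cc1[nH]c2ccccc2c(=O)c1Br`: 8.19 10^-6 cm/s
- compound 2 `Cc1[nH]c2ccc(Cl)cc2c(=O)c1Br`: 84.5 10^-6 cm/s

Both compounds were read in an ADME assay for permeability, using PAMPA, at pH 4; on this read-out lower numbers stand for lower permeability and higher numbers for higher permeability. For the measured compounds named here, of the two numbers, the higher belongs to compound 2 at 84.5 10^-6 cm/s, and its only neighbour is compound 1 at 8.19 10^-6 cm/s. The gap between the two lies beyond the scatter.

Next in this assay comes compound 3 `Cc1[nH]c2ccc(F)cc2c(=O)c1Br`. The change is fluoro in place of chloro on an aromatic carbon.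

Going by the values given here, only one measured step bears on this: a 10-fold higher number from compound 1 to compound 2 (1.01 log units; beyond the scatter), a large step beyond the scatter, with chloro in place of hydrogen on an aromatic carbon. No fluoro compound has been measured yet, so the size of this swap is not shown directly, and a single step sets no trend. The working expectation is that compound 3 falls between the two measured compounds, nearer the middle of the gap given by a 10-fold higher number from compound 1 to compound 2 (1.01 log units; beyond the scatter) than at either end. A lower number than for compound 2 is therefore expected, probably beyond the scatter. The estimated step is a 3.4-fold lower number from compound 2 to compound 3 (0.53 log units; beyond the scatter). For compound 3 the expected value is 25 10^-6 cm/s, with an estimated range of 9 10^-6 cm/s to 70 10^-6 cm/s.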

Compound 3, apparent permeability: 16.2 10^-6 cm/s
Compound 3: the middle estimate sits 1.5-fold (0.19 log units) above what was measured, and the stated range covers the measured number.
By their numbers in this assay, from the lowest: compounds 1 and 3 (each within the scatter of the next); then compound 2.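

In this assay, the identity of the halogen on this aromatic carbon matters: fluoro in place of chloro gives a 5.2-fold lower number from compound 2 to compound 3 (0.72 log units; beyond the scatter), so the large rise seen with chloro, a 10-fold higher number from compound 1 to compound 2 (1.01 log units; beyond the scatter), does not extend to both halogens shown. Fluoro in place of hydrogen at the same place gives a 2.0-fold higher number from compound 1 to compound 3 (0.30 log units; within the scatter), so the two cannot be told apart on this read-out, and among the three compounds only the chloro compound stands apart. Nothing available accounts for the difference between chloro and fluoro at this place.

Still open, as far as these compounds go, is how other groups on this aromatic carbon would read, whether a methyl, a methoxy, a trifluoromethyl or an amine, and so whether any of them would sit with chloro or remain level with hydrogen and fluoro. Also open is whether chloro would give a comparable step on another aromatic carbon of the shared core, since the three compounds shown vary at a single place and give only one comparison for each pair of groups.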